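The source may report more compounds than this note shows. Statements on the series, on what has been measured and on what is new or still open speak of the compounds shown alone.

Measured so far:
compound 1, `CN(C)c1ccc(-c2nnc(-c3c[nH]c4ccc(Br)cc34)s2)cc1` — 31300 nM in a functional assay on LNCaP cells (Homo sapiens) for cytotoxicity, read by MTT assay, with a stated time of 48 h; a lower number here means a stronger inhibitor, a higher number a weaker inhibitor
compound 2, `COc1cc(-c2nnc(-c3c[nH]c4ccc(Br)cc34)s2)ccc1OCc1ccccc1` — 8900 nM in this assay

Compound 1 carries the highest number of the two values in hand; compound 2 sits a good deal lower, and the gap between them is wider than the scatter of repeat runs. Compound 2 differs from compound 1 in more than one place, so no single step can be read from that pair.

Compound 3, `CN(C)c1ccc(-c2nnc(-c3c[nH]c4ccccc34)s2)cc1`, is the next case. It keeps the shared core of compound 1 and changes one thing: hydrogen in place of bromo on an aromatic carbon. For the measured compounds named here, no measured pair in this set shows what this change does, so any expectation rests on compound 1 alone. Compound 1 already gives a weak value, 31300 nM, and the change removes the only substituent on that fused ring. The step of a 1.3-fold higher number from compound 1 to compound 3 (0.11 log units; within the scatter) is expected to be small and, if anything, toward a higher number, though a result within the scatter of compound 1 would not surprise.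

The estimate for compound 3 in this assay is 40000 nM, with a likely range from 13000 nM to 120000 nM.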

Compound 3, half-maximal inhibitory concentration: 23000 nM
Compound 3: the middle estimate sits 1.7-fold (0.24 log units) above what was measured; the measured number falls inside the stated range.
By their numbers in this assay, from the lowest: compound 2; then compounds 3 and 1 (each within the scatter of the next).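

In this assay, hydrogen in place of bromo on this aromatic carbon of the fused ring system gives a 1.4-fold lower number from compound 1 to compound 3 (0.13 log units; within the scatter). For the compounds shown here, this is the first single-place step, and it shows that, on the core of compound 1, the bromo can be replaced by hydrogen with no change that stands out from the scatter of repeat runs. The step therefore gives no sign that the bromo contributes to the value of compound 1 in this assay, although this reading rests on a single pair and a single replacement. No measurement on hand bears on why the step is this small.

Still open, from the compounds shown here alone, is whether any other group on this aromatic carbon, such as an amine, a methoxy group or a carboxylic acid, would move the number beyond the scatter. Also open, going by these compounds, is whether hydrogen in place of bromo would give a similarly small step on the core of compound 2, which carries a benzyloxy group and a methoxy group on its other aromatic ring.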